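The source may hold more compounds than are shown below. What is called first, only, known or untested is meant among the compounds shown, and "the series" means these compounds.

Among the compounds with values here, compound 2, `Cc1n[nH]c(-c2ncc3c(N4CCCCS4(=O)=O)ccnc3c2O)n1`, gives the higher of the two numbers measured so far in a physicochemical assay for solubility, measured as kinetic solubility; a higher number here means a more soluble compound, a lower number a less soluble compound: compound 2 reaches 250000 nM, while compound 1, `Cc1n[nH]c(-c2ncc3c(N4CCCC4=O)ccnc3c2O)n1`, gives 109000 nM. Within the data shown here, the only measured step, a 2.3-fold higher number from compound 1 to compound 2 (0.36 log units; beyond the scatter), connects these two. Compound 3, `Cc1n[nH]c(-c2ncc3c(-c4ccccc4)ccnc3c2O)n1`, has not yet been measured. Its difference from compound 2 is a group of 6 heavy atoms (6 carbon; one six-membered aromatic ring of carbon only) in place of a group of 8 heavy atoms (4 carbon, 1 nitrogen, 2 oxygen, 1 sulfur; one six-membered non-aromatic ring with 2 hetero atoms), on an aromatic carbon. Among the measured compounds shown here, no measured step swaps in phenyl, so the step from compound 1 to compound 2 bears on it only by showing that exchanging one ring at this position for another can move the number beyond the scatter while staying modest. Compound 3 is expected to give a lower number than compound 2 in this assay, with an estimated step of an 8.3-fold lower number from compound 2 to compound 3 (0.92 log units; beyond the scatter), larger than the measured one. The estimate for compound 3 is 30000 nM, within a range from 8000 nM to 100000 nM.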

Compound 3, solubility: 160000 nM
Estimate against measurement, compound 3: 5.3-fold (0.73 log units) below; measured number above the stated range.
By their numbers in this assay, from the lowest: compounds 1, 3 and 2 (each within the scatter of the next, the first and the last beyond it).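

In this assay, putting phenyl on this aromatic carbon gives a 1.6-fold lower number from compound 2 to compound 3 (0.19 log units; within the scatter), and the comparison with the other ring gives a 1.5-fold higher number from compound 1 to compound 3 (0.17 log units; within the scatter). This position therefore accepts an aromatic ring of carbon only, with no hydrogen-bond acceptors, and the resulting number cannot be told apart from that of either non-aromatic ring, although those two rings differ from each other beyond the scatter. Nothing available explains why the swap to phenyl leaves the number within the scatter of both.

As far as these compounds go, it remains open whether a different kind of group on this carbon, such as an amine, a carboxylic acid or a longer chain, would stay within the same scatter. It is also unknown whether a phenyl bearing a further group, such as a fluorine atom or a methoxy group, would do so.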